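The source may hold more compounds than are shown below. What is called first, only, known or untested is meant among the compounds shown, and "the series" means these compounds.

In an ADME assay (liver) for metabolic stability, with Liver microsome (Homo sapiens) as the target, using microsomes (a higher number here means faster removal of the compound, a lower number slower removal), compound 1 `CNC(=O)c1cnc(Oc2cc(C(=O)Nc3cnc(C)cn3)cc3oc(C)cc23)cn1` gives 10.1 mL/min/kg and compound 2 `Cc1cnc(NC(=O)c2cc(Oc3cnc(C(=O)N4CCCCC4)cn3)c3cc(C)oc3c2)cn1` gives 18.2 mL/min/kg. Compound 3 `Cc1ccc(NC(=O)c2cc(Oc3cnc(C(=O)N(C)C)cn3)c3cc(C)oc3c2)nc1` is known only by a limit, < 10.6 mL/min/kg. That result is the limit of < 10.6 mL/min/kg in this assay, at which 1 of the 3 values shown sits, so compound 3 offers a limit and not a number to start from.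

Compound 4 `COc1cnc(NC(=O)c2cc(Oc3cnc(C(=O)N(C)C)cn3)c3cc(C)oc3c2)cn1` keeps the rest of compound 3 and carries 5-methoxypyrazin-2-yl in place of 5-methylpyridin-2-yl on an amide-type nitrogen.

Going by the values given here, no measured step covers a change at this place. Among the compounds with values here, the only step available is a 1.8-fold higher number from compound 1 to compound 2 (0.26 log units; within the scatter), which puts piperidin-1-yl in place of methylamino on a carbonyl carbon. It lies within the scatter and bears on the present change only indirectly, as a sign that this assay has so far moved little across these compounds. Within the data shown here, with that step as the sole guide, no shift beyond the scatter is expected, in either direction, and the expected step is an at least 1.0-fold higher number from compound 3 to compound 4 (0.01 log units; that floor lies within the scatter). This expectation is weakly founded, since it starts from a limit and rests on a change made elsewhere in the molecule. For compound 4 the estimated value is 11 mL/min/kg, with an expected range of 6 mL/min/kg to 20 mL/min/kg.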

Compound 4, clearance in the Liver microsome assay: < 8 mL/min/kg
Compound 4 ended at the assay's limit; the forecaster's own chance of this, stated with the estimate: 40%; at least 1.3-fold (0.13 log units) between middle value and limit.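

In the Liver microsome assay, compound 3 is known only as a limit of the assay, < 10.6 mL/min/kg. In the Liver microsome assay, compound 4 is also known only as a limit of the assay, < 8 mL/min/kg. Going by these compounds alone, no step between these two compounds can be read. The compounds shown leave open whether, and in which direction, clearance shifts when 5-methoxypyrazin-2-yl stands in place of 5-methylpyridin-2-yl on an amide-type nitrogen. In a physicochemical assay for solubility, measured as kinetic solubility (on this read-out higher numbers stand for higher solubility and lower numbers for lower solubility), compound 3 gives 215000 nM and compound 4 gives 25000 nM. In the physicochemical assay, the same change gives an 8.6-fold lower number from compound 3 to compound 4 (0.93 log units; beyond the scatter).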